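Cytotoxicity of a cyclopentyl-to-isopropylcyclohexyl exchange

This account rests on a few compounds, and the source may have more. Where it says the series, first, only, none or still open, it means among the compounds named here.

Compound 1 `CCC1=C(C(=O)CCC2CCCCC2)[C@H](c2ccc(O)c(Cl)c2)NC(=O)N1` gives > 10000 nM in an ADME assay on cells (Homo sapiens) for cytotoxicity (on this read-out higher numbers stand for lower toxicity in this test and lower numbers for higher toxicity in this test), a limit of the assay rather than a number. Compound 2 `CCC1=C(C(=O)CCc2ccccc2)[C@H](c2ccc(O)c(Cl)c2)NC(=O)N1` likewise reaches only the limit > 10000 nM. Compound 3 `CCC1=C(C(=O)CC2CCCC2)[C@H](c2ccc(O)c(Cl)c2)NC(=O)N1` also stops at the limit > 10000 nM, so its standing cannot be placed more closely. The steps a step that the two limits leave unreadable from compound 1 to compound 2, a step that the two limits leave unreadable from compound 1 to compound 3 and a step that the two limits leave unreadable from compound 2 to compound 3 therefore carry no readable size, because of the limit of > 10000 nM in this assay, at which 3 of the 3 values shown sit. Compound 4 `CCC1=C(C(=O)CC2CCC(C(C)C)CC2)[C@H](c2ccc(O)c(Cl)c2)NC(=O)N1` differs from compound 3 by 4-isopropylcyclohexyl in place of cyclopentyl on a saturated chain carbon bound to a carbonyl carbon. Among the compounds with values here, no measured step speaks for or against this change, so the estimated step that the limit leaves unreadable from compound 3 to compound 4 is expected to stay within the scatter. Compound 4 is expected at 15000 nM, between 5000 nM and 50000 nM, most likely again reported as a limit.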

Compound 4, half-maximal cytotoxic concentration: > 10000 nM
Compound 4: a limit, no number (the forecaster's own chance of this, stated with the estimate: 75%); the middle value lies beyond the limit too.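

Within the data shown here, compound 4 also stops at a limit rather than a number, so no step linking it to compound 1, compound 2 or compound 3 can be read: the limit of > 10000 nM in this assay, at which 4 of the 4 values shown sit. The compounds shown leave open whether these side chains differ at all in this assay.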